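Carbonyl carbon substituent change from compound 3 to compound 4

The source may hold more compounds than are shown below. What is called first, only, known or untested is meant among the compounds shown, and "the series" means these compounds.

compound 1 `CCN(CC)CCNC(=O)c1ccc(C(CC)(CC)c2ccc(OCC(=O)C(C)(C)C)c(C)c2)n1CC`: 2500 nM
compound 2 `CCn1c(C(=O)NCCN)ccc1C(CC)(CC)c1ccc(OCC(=O)C(C)(C)C)c(C)c1`: 2500 nM
compound 3 `C#CCNC(=O)c1ccc(C(CC)(CC)c2ccc(OCC(O)C(C)(C)C)c(C)c2)n1CC`: 4400 nM

In an ADME assay on L02 cells (Homo sapiens) for cytotoxicity, read by MTT assay, with a stated time of 48 h (on this read-out higher numbers stand for weaker inhibition and lower numbers for stronger inhibition), compound 3 gives 4400 nM and lies within the scatter of both compound 1 and compound 2. Compound 4 `C#CC(C)OC(=O)c1ccc(C(CC)(CC)c2ccc(OCC(O)C(C)(C)C)c(C)c2)n1CC` carries (1-methylprop-2-yn-1-yl)oxy in place of propargylamino on a carbonyl carbon. Going by the values given here, the one measured step of no change at the digits printed from compound 1 to compound 2 (within the scatter) puts amino in place of diethylamino and stays within the scatter. Among the compounds with values here, no measured step replaces propargylamino, so the evidence is thin. The expected step is a 1.1-fold lower number from compound 3 to compound 4 (0.04 log units; within the scatter) (nothing beyond the scatter is expected in this assay). The estimate for compound 4 is 4000 nM (expected range 1800 nM to 9000 nM).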

Compound 4, half-maximal inhibitory concentration: 23700 nM
The estimate for compound 4 lay 5.9-fold (0.77 log units) below the measured number; the whole stated range lies below it.
By their numbers in this assay, from the lowest: compounds 1, 2 and 3 (each within the scatter of the next); then compound 4.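

In this assay the substituent on this carbonyl carbon does affect the number: (1-methylprop-2-yn-1-yl)oxy in place of propargylamino gives a 5.4-fold higher number from compound 3 to compound 4 (0.73 log units; beyond the scatter) and is the only step shown beyond the scatter. The other step, amino in place of diethylamino, gives no change at the digits printed from compound 1 to compound 2 (within the scatter) and lies within it. Nothing available explains the rise.

The change swaps nitrogen for oxygen, removes a hydrogen-bond donor and adds a methyl all at once, so these contributions remain unseparated. Plain propargyloxy or 1-methylprop-2-yn-1-ylamino on the same carbonyl carbon would separate them.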